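The compounds below may be only part of what the source reports. "The series", "measured", "known", "first", "only" and "open" are said of these compounds alone.

Measured half-lives in an in vitro ADME assay on microsomes from liver (Homo sapiens) for metabolic stability, read by LC-MS, tested at 1 uM; on this read-out lower numbers stand for a shorter-lived compound and higher numbers for a longer-lived compound:

Compound 1 `CC(C)N/C(=N\c1nccn1C(C)(C)C)Nc1ccc(Cl)c(Cl)c1` gives 0.8 h.
Compound 2 `CC(C)N1CCN=C1/N=C(/Nc1ccc(Cl)c(Cl)c1)N1CCCCC1` returns only a limit of the assay, > 1 h.
Compound 3 `CC(C)C(=O)N/C(=N/c1nccn1C(C)C)Nc1ccc(Cl)c(Cl)c1` likewise returns only a limit of the assay, > 1 h.

Compound 3 therefore stands at the upper bound of what this assay reports, and its value is a limit rather than a number; the same holds for (the limit of > 1 h in this assay, at which 2 of the 3 values shown sit). Within the data shown here, compound 1 is the only compound of the three with a numeric half-life.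

Compound 4 `CCC(CC)C(=O)N/C(=N/c1nccn1C(C)C)Nc1ccc(Cl)c(Cl)c1` differs from compound 3 in one place: pentan-3-yl in place of isopropyl on a carbonyl carbon. Among the measured compounds shown here, no measured pair isolates this change, so no step of known size is available to set it against. The step from compound 3 to compound 4 is expected to stay within the scatter, in no particular direction, which makes a step that the limit leaves unreadable from compound 3 to compound 4 an expected step of essentially nil. Compound 4 is accordingly estimated at 1.2 h, with a range from 0.5 h to 3 h. A fair chance remains that this assay again reports only a limit for compound 4.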

Compound 4, half-life: > 1 h
Compound 4 was reported as a limit; the forecaster's own chance of this, stated with the estimate: 55%; the middle value lies beyond the limit too.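

Among these compounds, compound 3 and compound 4 both return only a limit in this assay, and no step between them can be read: the limit of > 1 h in this assay, at which 3 of the 4 values shown sit. Still open, on these data alone, is whether pentan-3-yl in place of isopropyl on a carbonyl carbon shifts the half-life at all, and what the actual half-lives of compound 3 and compound 4 are.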